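The source may hold more compounds than are shown below. What is called first, only, known or untested is meant among the compounds shown, and "the series" means these compounds.

In a functional assay on the whole organism (brain) for inhibition, with Mus musculus as the target (on this read-out higher numbers stand for an effect only at larger amounts of compound and lower numbers for an effect already at smaller amounts), three related amines have been tested so far. Compound 1 `CN(C)CC/C=C(\c1ccc(Br)cc1)c1cccnc1` gives 95 umol/kg. Within the data shown here, compound 3 `CNCC/C=C(\c1ccc(Br)cc1)c1cccnc1` gives 98 umol/kg, which lies within the scatter of compound 1, the only other true number available. Compound 2 `CN(C)CC/C=C(/c1ccc(Br)cc1)c1cccnc1` reads > 95 umol/kg, and this is a limit of the assay, not a number.

Compound 4 `CNCC/C=C(/c1ccc(Br)cc1)c1cccnc1` has not been measured yet, and it relates to compound 3 as follows: the two compounds have the same atoms and bonds and differ only in configuration as drawn: 1 of 1 stereo elements differ; a double bond is drawn E in compound 3 and Z in compound 4. The closest guide is the same double-bond switch in the other pair, a number no lower from compound 1 to compound 2 (the limit leaves the size open), which shows the direction but not the size. The other measured step, hydrogen in place of methyl on an amine nitrogen, is a 1.0-fold higher number from compound 1 to compound 3 (0.01 log units; within the scatter), so compound 4 is expected to behave much like compound 2. The expected 1.2-fold higher number from compound 3 to compound 4 (0.09 log units; within the scatter) is a small move towards a higher number, and the assay may well report only a limit. For compound 4 the estimated value is 120 umol/kg, with an expected range from 60 umol/kg to 250 umol/kg.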

Compound 4, dose for half-maximal effect: > 98 umol/kg
Compound 4: only a limit was reported (the forecaster's own chance of this, stated with the estimate: 60%); the middle value is on the limit's open side.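

The double-bond change has now been tried on a second amine, and in this assay it gives a number no lower from compound 3 to compound 4 (the limit leaves the size open). Compound 4 gives > 98 umol/kg, which is a limit and not a number. Neither of the two E and Z pairs, one with two methyl groups on the amine nitrogen and one with a single methyl, shows the Z compound with a lower number, and in the new pair only the configuration changes: the fact that compounds 3 and 4 differ only in the configuration as drawn

How large the step to compound 4 from compound 3 is, and how compound 2 and compound 4 compare, cannot be read from these limits. Also open, on these data alone, is whether the same direction would hold with a primary amine, a longer chain between the amine and the double bond, or chlorine in place of the bromine.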